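Removing the methoxy group from the arylpiperazine of compound 2

The source may hold more compounds than are shown below. What is called first, only, known or untested is meant among the compounds shown, and "the series" means these compounds.

Three members of this series have numbers in a functional assay on aorta for antagonist activity at Alpha-1D adrenergic receptor (Rattus norvegicus); on this read-out higher numbers stand for weaker binding and lower numbers for tighter binding. Compound 1 `CNC(=O)c1cccnc1NCCCN1CCN(c2ccccc2OC)CC1` gives 3.16 nM; compound 2 `COc1ccccc1N1CCN(CCCNc2ncccc2C(=O)N(C)C)CC1` gives 20 nM; compound 3 `COc1ccccc1N1CCN(CCCNc2ncc(C#N)cc2C(=O)N(C)C)CC1` gives 20 nM. Compound 2 and compound 3 are level at the digits shown, together the highest numbers of the three, and compound 1 is the lowest, with a 6.3-fold higher number from compound 1 to compound 2 (0.80 log units; beyond the scatter). The other measured step is no change at the digits printed from compound 2 to compound 3 (within the scatter), which does not leave the scatter.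

Compound 4 `CN(C)C(=O)c1cccnc1NCCCN1CCN(c2ccccc2)CC1` is not yet measured. It differs from compound 2 by hydrogen in place of methoxy on an aromatic carbon. Neither measured step touches this part of the molecule: the step from compound 1 to compound 2 changes the amide nitrogen, and the step from compound 2 to compound 3 changes the other aromatic ring. Going by the values given here, there is therefore no step that bears directly on the change, and nothing in the data points to a shift in one direction. The working expectation is a small step at most, a 2.0-fold higher number from compound 2 to compound 4 (0.30 log units; within the scatter), with a range wide enough to allow a modest change either way. The number expected for compound 4 in this assay is 40 nM, between 13 nM and 125 nM.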

Compound 4, dissociation constant: 15.9 nM
The estimate for compound 4 lay 2.5-fold (0.40 log units) above the measured number, and the stated range covers the measured number.
By their numbers in this assay, from the lowest: compound 1; then compounds 4, 2 and 3 (each within the scatter of the next).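

In this assay, hydrogen can stand in place of methoxy on the six-membered aromatic ring of carbon only, with a 1.3-fold lower number from compound 2 to compound 4 (0.10 log units; within the scatter), so the read-out does not separate 2-methoxyphenyl from phenyl on the background of compound 2. Going by these compounds alone, the earlier steps concerned the amide nitrogen and the other aromatic ring, which makes this the first reading at this position; it shows that the methoxy group, with its 2 heavy atoms and its hydrogen-bond acceptor, is not required to keep the number at the level of compound 2. No supporting measurement is available to interpret this result, so it stands as an observation only.

Open, on these data alone, is how this position responds to other groups, such as fluorine, chlorine, hydroxyl or ethoxy, since methoxy and hydrogen alone say little about the wider range of substituents there. Also open, as far as these compounds go, is whether the same exchange reads the same way on the core of compound 1, which gives 3.16 nM, or on the nitrile-bearing core of compound 3.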